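The Step From Compound 3 to an Iodinated Compound 4

The source may hold more compounds than are shown below. What is called first, only, known or untested is meant among the compounds shown, and "the series" means these compounds.

Compound 3 `COc1ccccc1Oc1c(N)nc(-c2ccccc2)nc1OCCO` carries a 2-hydroxyethoxy group on the shared core. Within the data shown here, in a functional assay on B16 cells (Mus musculus) for cytotoxicity, read by CCK-8 assay, with a stated time of 24 h (a higher number here means a weaker inhibitor, a lower number a stronger inhibitor), compound 3 gives 31100 nM, the highest of the three numbers measured so far. Compound 1 `COc1ccccc1Oc1c(N)nc(-c2ccccc2)nc1Cl` gives 4610 nM in this assay, and compound 2 `COc1ccccc1Oc1c(N)nc(-c2ccccc2F)nc1Cl` gives 13800 nM. The step of a 6.7-fold higher number from compound 1 to compound 3 (0.83 log units; beyond the scatter) separates compound 3 from compound 1. Compound 4 `COc1ccccc1Oc1c(N)nc(-c2cccc(I)c2)nc1OCCO` differs from compound 3 in one place: iodo in place of hydrogen on an aromatic carbon. Among the measured compounds shown here, only one measured step touches the same six-membered aromatic ring of carbon only: a 3.0-fold higher number from compound 1 to compound 2 (0.48 log units; beyond the scatter). That step was modest and weakened inhibition, but iodo is not fluoro, so its bearing on the present change is loose. A small weakening, or no change beyond the scatter, is therefore expected in this assay. For compound 4 the expected value is 38000 nM, with a range from 12000 nM to 110000 nM. This estimate corresponds to an expected step of a 1.2-fold higher number from compound 3 to compound 4 (0.09 log units; within the scatter).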

Compound 4, half-maximal inhibitory concentration: 20300 nM
The estimate for compound 4 lay 1.9-fold (0.27 log units) above the measured number, and the stated range covers the measured number.
By their numbers in this assay, from the lowest: compound 1; then compounds 2, 4 and 3 (each within the scatter of the next, the first and the last beyond it).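

In this assay, iodo can sit on this aromatic carbon, meta to a large group, with only a 1.5-fold lower number from compound 3 to compound 4 (0.19 log units; within the scatter), so replacing hydrogen with this one heavy atom on compound 3 gives no change that can be told from repeat-measurement noise. Among these compounds, the only earlier step on this ring, a 3.0-fold higher number from compound 1 to compound 2 (0.48 log units; beyond the scatter), lay beyond the scatter, but it involved fluoro on a parent with chloro rather than 2-hydroxyethoxy, so the two steps cannot be read as a direct test of one another. Nothing measured here explains why the iodo step stays within the scatter. As far as these compounds go, it remains open whether an amine or a carboxylic acid in place of iodo at this same carbon would shift the number beyond the scatter. From the compounds shown here alone, it is also open whether iodo would behave the same way on compound 1, which carries chloro instead of 2-hydroxyethoxy.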